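Chain Extension on a Bicyclic Ester: Expecting Compound 4

The source may report more compounds than this note shows. Statements on the series, on what has been measured and on what is new or still open speak of the compounds shown alone.

Measured so far in a functional assay on HeLa S3 cells (Homo sapiens) for cytotoxicity; a lower number here means a stronger inhibitor, a higher number a weaker inhibitor:
Compound 1 `CCCC(=O)O[C@]12C=CC(=O)C[C@H]1OCC2`: 2.7 ug/mL
Compound 2 `CCCCCC(=O)O[C@]12C=CC(=O)C[C@H]1OCC2`: 1.8 ug/mL
Compound 3 `CCCCCC(=O)O[C@]12C=CC(O)C[C@H]1OCC2`: 5.3 ug/mL

Compound 2 differs from compound 1 by ethyl in place of hydrogen on a saturated chain carbon, three bonds along the chain from a carbonyl carbon; that change gave a 1.5-fold lower number from compound 1 to compound 2 (0.18 log units; within the scatter). Compound 3 carries a different core: how it differs from the core of compound 1 is not broken down here, and the values of compound 3 and compound 2 differ beyond the scatter, while those of compound 3 and compound 1 do not. Compound 4 `CCCCCCCC(=O)O[C@]12C=CC(O)C[C@H]1OCC2` differs from compound 3 by ethyl in place of hydrogen on a saturated chain carbon, five bonds along the chain from a carbonyl carbon. This is the same kind of change as from compound 1 to compound 2, but the place is not identical: there it sat three bonds along the chain from a carbonyl carbon, here five bonds along. On the strength of a 1.5-fold lower number from compound 1 to compound 2 (0.18 log units; within the scatter), the step of a 1.3-fold lower number from compound 3 to compound 4 (0.12 log units; within the scatter) is expected to stay small. Compound 4 is therefore estimated at 4 ug/mL, between 2 ug/mL and 8 ug/mL.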

Compound 4, half-maximal inhibitory concentration: 3.5 ug/mL
Estimate against measurement, compound 4: 1.1-fold (0.06 log units) above; low and high end bracket the measured number.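

Extending the chain on the core of compound 3 gave a 1.5-fold lower number from compound 3 to compound 4 (0.18 log units; within the scatter) in this assay. Set beside the earlier step, the change carries over from one core to the other with no visible difference: the same change on two cores in this assay, a 1.5-fold lower number (0.18 log units; within the scatter) from compound 1 to compound 2 and a 1.5-fold lower number (0.18 log units; within the scatter) from compound 3 to compound 4, 1.0-fold (0.00 log units) apart, within the scatter of two such steps. For the compounds shown here, this shows only that the step stays small on both cores; each step lies within the scatter, so neither shows a real gain, and two pairs, with the change at different places along the chain, give no rule for the whole series.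

The compounds shown leave open whether a longer chain would move the number beyond the scatter. They also leave open what an amine or a carboxylic acid in place of the ethyl would do.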